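Chloro in Place of Trifluoromethyl on a Fused Core

The compounds below may be only part of what the source reports. "The series", "measured", "known", "first", "only" and "open" are said of these compounds alone.

Compound 1, `O=c1c(-c2nn[nH]n2)c[nH]c2c(C(F)(F)F)cccc12`, gives the lowest of the two numbers recorded so far. In a functional assay on the whole organism (strain Sprague-Dawley) for inhibition, with Rattus norvegicus as the target (a lower number here means that less compound is needed, a higher number that more compound is needed for the effect), compound 1 gives 0.156 mg/kg. Compound 3, `Cc1ccc2cc(-c3nn[nH]n3)cnc2c1C`, gives 1 mg/kg in this assay, a step from compound 1 that lies beyond the usual scatter of repeated measurements. Compound 2, `COc1ccc2c(O)c(C(=O)O)cnc2c1`, reaches only a limit of the assay in this assay, > 50 mg/kg, and this is the limit of > 50 mg/kg in this assay, at which 1 of the 3 values shown sits; it is not a number.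

The unmeasured compound 4, `O=c1c(-c2nn[nH]n2)c[nH]c2c(Cl)cccc12`, keeps the core of compound 1 and differs from it in one place: chloro in place of trifluoromethyl on an aromatic carbon. Within the data shown here, no measured pair in this set shows the same change, so the size of the step is not known from data. A modest step is expected, in either direction, and most likely none beyond the scatter.

Compound 4 is therefore expected to give about 0.25 mg/kg in this assay, with a range from 0.08 mg/kg to 0.8 mg/kg. This estimate means a 1.6-fold higher number from compound 1 to compound 4 (0.20 log units; within the scatter).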

Compound 4, minimum effective dose: 0.078 mg/kg
For compound 4 the middle estimate is 3.2-fold (0.51 log units) above the measured one; measured number below the stated range.
By their numbers in this assay, from the lowest: compounds 4 and 1 (each within the scatter of the next); then compound 3. At a limit, above all of these: compound 2.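

Among these compounds, this pair is the first in the set to differ in one place only, so it gives the first direct reading of what a change on this aromatic carbon does. In this assay the exchange of trifluoromethyl for chloro gives a 2.0-fold lower number from compound 1 to compound 4 (0.30 log units; within the scatter) and therefore shows no real difference between the two groups, even though one group has several heavy atoms and the other has just one. No measurement shown here tells why these two groups give such similar numbers.

Going by these compounds, it remains open whether an amine, a longer carbon chain or a plain hydrogen on this aromatic carbon would give a similar number. A single pair also cannot show whether the same exchange would behave alike on a different core.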